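Solubility of a nitrile analogue in the shared pyridone series

The compounds below may be only part of what the source reports. "The series", "measured", "known", "first", "only" and "open" are said of these compounds alone.

Compound 1, `CNC(=O)c1cc(C(=O)NC2CC2)cn(CC2CCOCC2)c1=O`, gives >= 165 ug/mL in a physicochemical assay for solubility; a lower number here means a less soluble compound, a higher number a more soluble compound; this value is a limit of the assay, not a number.
Compound 2, `CNC(=O)c1cc(C(=O)NC2CC2)cn(Cc2cccc3cc[nH]c23)c1=O`, gives >= 144 ug/mL in this assay; this value too is a limit.
Compound 3, `CNC(=O)c1cc(C(=O)NC2CC2)cn(Cc2cccc([C@@H](C)O)c2)c1=O`, gives >= 131 ug/mL in this assay; this value is a limit as well.

Compound 3 therefore stands only at a limit, (the limit of >= 131 ug/mL in this assay, at which 1 of the 3 values shown sits), and the two other compounds also sit at limits, the limit of >= 144 ug/mL in this assay, at which 1 of the 3 values shown sits, and (the limit of >= 165 ug/mL in this assay, at which 1 of the 3 values shown sits). Because all three are limits, the steps between them cannot be read: a step that the two limits leave unreadable from compound 1 to compound 2, a step that the two limits leave unreadable from compound 1 to compound 3 and a step that the two limits leave unreadable from compound 2 to compound 3 all remain of unknown size and direction.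

Compound 4, `CNC(=O)c1cc(C(=O)NC2CC2)cn(Cc2cccc(C#N)c2)c1=O`, differs from compound 3 in one place: cyano in place of 1-hydroxyethyl on an aromatic carbon. Among the compounds with values here, none of the measured steps bears on this change, since none of them could be read, so no size or direction can be drawn from them.

For compound 4 in this assay the estimate is 80 ug/mL, with a range from 30 ug/mL to 165 ug/mL. The expected step from compound 3 is an at least 1.6-fold lower number from compound 3 to compound 4 (0.21 log units; that floor lies within the scatter), a downward move that may still leave compound 4 at the assay limit.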

Compound 4, solubility: >= 148 ug/mL
Compound 4 was reported as a limit (the forecaster's own chance of this, stated with the estimate: 35%); middle value at least 1.8-fold (0.26 log units) from the limit.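

Compound 4 gives >= 148 ug/mL in this assay, which is a limit of the assay and not a number. Compound 1, compound 2 and compound 3 also sit at limits, so no step among these four compounds can be read. The compounds shown leave open how much solubility separates them, including whether cyano in place of 1-hydroxyethyl shifts it at all.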